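This account rests on a few compounds, and the source may have more. Where it says the series, first, only, none or still open, it means among the compounds named here.

Compound 2 `COc1ccc(/C=N\NC(=S)NC(C)(C)CCC[C@](C)(O)[C@@H]2CC=C(C)CC2)cc1` gives in a functional assay on NCI/ADR cells (Homo sapiens) for cytotoxicity, read by sulforhodamine B assay (on this read-out lower numbers stand for stronger inhibition of growth and higher numbers for weaker inhibition of growth), a value of 57000 nM, the highest of the two numbers recorded so far. For the measured compounds named here, its nearest neighbour is compound 1 `CC1=CC[C@@H]([C@@](C)(O)CCCC(C)(C)NC(=S)N/N=C\c2ccc(C)cc2)CC1`, which in this assay gives 30500 nM; the single measured step, a 1.9-fold higher number from compound 1 to compound 2 (0.27 log units; within the scatter), exchanges methyl for methoxy on an aromatic carbon and stays within the scatter. Compound 3 `CC1=CC[C@@H]([C@@](C)(O)CCCC(C)(C)NC(=S)N/N=C\c2ccc(O)cc2)CC1` is the next member of the series and differs from compound 2 by hydrogen in place of methyl on an oxygen on an aromatic ring. Going by the values given here, the one step that bears on this change is the methyl-to-methoxy exchange at the same aromatic position, and it produced no difference beyond the scatter; no measured step here involves a hydroxy group at all. On that basis compound 3 is expected to land close to compound 2, with an expected step of a 1.3-fold lower number from compound 2 to compound 3 (0.10 log units; within the scatter) that does not exceed the scatter. Compound 3 is therefore estimated at 45000 nM, within a range from 18000 nM to 110000 nM.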

Compound 3, concentration for total growth inhibition: 6070 nM
The estimate for compound 3 lay 7.4-fold (0.87 log units) above the measured number; the whole stated range lies above it.
By their numbers in this assay, from the lowest: compound 3; then compounds 1 and 2 (each within the scatter of the next).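

Both a 9.4-fold lower number from compound 2 to compound 3 (0.97 log units; beyond the scatter) and a 5.0-fold lower number from compound 1 to compound 3 (0.70 log units; beyond the scatter) lie beyond the scatter in this assay and give the first differences of that kind in this series. Methyl and methoxy on this aromatic carbon could not be told apart, so the earlier compounds gave no sign that the group here matters, whereas the hydroxy of compound 3 sets it clearly below both. Removing the methyl from the oxygen of the 4-methoxyphenyl group is thus a small change that moves the number well beyond the scatter, and nothing measured here accounts for that step.

The compounds shown leave open whether this lower number is specific to hydroxy, or whether an amine or a carboxylic acid on the same aromatic carbon would also separate from compound 1 and compound 2. They also leave open whether an ethoxy group would stay with the methoxy of compound 2.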